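Methoxy to fluoro on the aryl of the fused thiadiazine

The source may report more compounds than this note shows. Statements on the series, on what has been measured and on what is new or still open speak of the compounds shown alone.

Measured compounds:
compound 1 `CC(c1ccc(-c2ccccc2)c(F)c1)c1n[nH]c(=S)n1N`: "not active" (no number reported)
compound 2 `COc1ccc(C2=Nn3c(nnc3C(C)c3ccc(-c4ccccc4)c(F)c3)SC2)cc1`: 4400 nM

In a functional assay on FOCUS cells (Homo sapiens) for inhibition, read by sulforhodamine B assay, with a stated time of 72 h (on this read-out lower numbers stand for stronger inhibition and higher numbers for weaker inhibition), compound 2 gives the only number shown in the series; compound 1 returns no single figure there. Compound 3 `CC(c1ccc(-c2ccccc2)c(F)c1)c1nnc2n1N=C(c1ccc(F)cc1)CS2` differs from compound 2 by fluoro in place of methoxy on an aromatic carbon. Without a measured step of this kind in the series, the change is expected to move this assay by a 1.1-fold higher number from compound 2 to compound 3 (0.06 log units; within the scatter), no further than the usual scatter, in no firm direction. For compound 3 the estimate is 5000 nM, with a range from 1500 nM to 15000 nM.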

Compound 3, half-maximal inhibitory concentration: 3500 nM
Compound 3: the middle estimate sits 1.4-fold (0.15 log units) above what was measured; low and high end bracket the measured number.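

In this assay, for the compounds shown here, the change from 4-methoxyphenyl to 4-fluorophenyl gives a 1.3-fold lower number from compound 2 to compound 3 (0.10 log units; within the scatter), the first measured step. At this position, the read-out does not separate fluoro from methoxy, although the step removes a hydrogen-bond acceptor as counted for the two groups. No measured evidence bears on this result.

Only these two groups are shown on this aromatic carbon. Going by these compounds, how an amine, a carboxylic acid or a longer alkoxy chain would read there remains open.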